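A few compounds are considered here, and "the series" means these few. Any claim that something is new, unique, unknown or untested is made for them only; others in the source may bear on it.

Of the compounds shown here, three sharing one core have been tested in a functional assay on HCT-116 cells (Homo sapiens) for cytotoxicity, read by MTT assay, with a stated time of 72 h; a lower number here means a stronger inhibitor, a higher number a weaker inhibitor. Compound 1 `COc1ncc(-c2ccc3nccc(-c4ccc(C)cc4)c3c2)cc1NS(=O)(=O)c1ccc(F)cc1F`, which carries hydrogen on the saturated chain carbon bound to an aromatic carbon, gives 2540 nM. Compound 2 `CCN(CC)Cc1ccc(-c2ccnc3ccc(-c4cnc(OC)c(NS(=O)(=O)c5ccc(F)cc5F)c4)cc23)cc1` gives 5 nM, and compound 3 `CCN(Cc1ccc(-c2ccnc3ccc(-c4cnc(OC)c(NS(=O)(=O)c5ccc(F)cc5F)c4)cc23)cc1)C1CCCCC1` gives 223 nM. Among these three numbers compound 3 stands second highest: the step of an 11-fold lower number from compound 1 to compound 3 (1.06 log units; beyond the scatter) is large, and the step of a 45-fold higher number from compound 2 to compound 3 (1.65 log units; beyond the scatter) is also large, so compound 3 sits between compound 1 and compound 2, further from compound 2.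

Compound 4 `CNCCN(C)Cc1ccc(-c2ccnc3ccc(-c4cnc(OC)c(NS(=O)(=O)c5ccc(F)cc5F)c4)cc23)cc1` is the next member. The change from compound 3 is methyl(2-(methylamino)ethyl)amino in place of cyclohexyl(ethyl)amino on a saturated chain carbon bound to an aromatic carbon. The measured steps that bear on this position are a 510-fold lower number from compound 1 to compound 2 (2.71 log units; beyond the scatter) and a 45-fold higher number from compound 2 to compound 3 (1.65 log units; beyond the scatter): the first shows that attaching an amine-bearing chain at this carbon moves the number far down, the second that the choice of groups on that amine nitrogen matters greatly. The entering group resembles the diethylamino of compound 2 more than the cyclohexyl(ethyl)amino of compound 3, so a large downward step a 15-fold lower number from compound 3 to compound 4 (1.17 log units; beyond the scatter) is expected in this assay, landing nearer compound 2 than compound 3. Compound 4 is therefore estimated at 15 nM, within a range from 4 nM to 80 nM.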

Compound 4, half-maximal inhibitory concentration: 51.8 nM
Estimate against measurement, compound 4: 3.5-fold (0.54 log units) below; measured number inside the range.
By their numbers in this assay, from the lowest: compound 2; then compound 4; then compound 3; then compound 1.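

Across this assay, the methyl(2-(methylamino)ethyl)amino group keeps much of the gain that an amine at this carbon gives over hydrogen, with a 49-fold lower number from compound 1 to compound 4 (1.69 log units; beyond the scatter), so this gain is not confined to the two amines with simple carbon groups on nitrogen. Replacing cyclohexyl(ethyl)amino with this ring-free group gives a 4.3-fold lower number from compound 3 to compound 4 (0.63 log units; beyond the scatter), yet the same group still falls short of diethylamino, with a 10-fold higher number from compound 2 to compound 4 (1.02 log units; beyond the scatter). For the compounds shown here, removing the ring therefore does not by itself recover the number of compound 2, and adding a second nitrogen to the chain brings no gain over that compound, so the groups on this amine still matter even among those without a ring.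

No measurement here explains why the three amines fall in this order. As far as these compounds go, the chain length and the second nitrogen change together in compound 4, so their separate contributions remain open, and a 2-methoxyethyl(methyl)amino group, which keeps a similar chain but ends in oxygen, or a piperazine ring, which holds both nitrogens in a ring, at this carbon would help to tell them apart.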